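A few compounds are considered here, and "the series" means these few. Any claim that something is new, unique, unknown or untested is made for them only; others in the source may bear on it.

Compound 1 `COc1ccccc1C(=O)NCc1ccc(CNS(=O)(=O)c2ccc([N+](=O)[O-])cc2)cc1`: 100 nM
Compound 2 `COc1ccccc1C(=O)NCc1ccc(CNS(=O)(=O)c2ccccc2C)cc1`: 1000 nM
Compound 3 `COc1ccccc1C(=O)NCc1ccc(CNS(=O)(=O)c2ccccc2F)cc1`: 1 nM

In an assay on MDA-MB-231 cells for displacement of a labelled ligand from C-X-C chemokine receptor type 4 (Homo sapiens), read by fluorescence and microscopy, with stated times of 10 min and 30 min (a higher number here means that more compound is needed for the effect, a lower number that less compound is needed), compound 3 has the lowest number of the three, with compound 1 the nearest and compound 2 the furthest. Compound 4 `COc1ccccc1C(=O)NCc1ccc(CNS(=O)(=O)c2cccc(Cl)c2)cc1` differs from compound 3 only at the sulfonyl sulfur: 3-chlorophenyl in place of 2-fluorophenyl on a sulfonyl sulfur. Going by the values given here, three measured steps bear on this position, each altering the group on that sulfonyl sulfur or a substituent on it: a 10-fold higher number from compound 1 to compound 2 (1.00 log units; beyond the scatter), a 100-fold lower number from compound 1 to compound 3 (2.00 log units; beyond the scatter) and a 1000-fold lower number from compound 2 to compound 3 (3.00 log units; beyond the scatter). Among the compounds with values here, the 2-fluorophenyl of compound 3 thus stands far apart from the other two groups, and no measured compound carries a 3-chlorophenyl or any chloro group, so the size of this step is not fixed by a matching pair. As both a 100-fold lower number from compound 1 to compound 3 (2.00 log units; beyond the scatter) and a 1000-fold lower number from compound 2 to compound 3 (3.00 log units; beyond the scatter) lowered the number on arriving at the 2-fluorophenyl, compound 4 is expected to give a higher number in this assay, with a step of a 30-fold higher number from compound 3 to compound 4 (1.48 log units; beyond the scatter). The estimate for compound 4 is 30 nM, in the range 3 nM to 300 nM.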

Compound 4, effective concentration (reported as EC, without a stated level of effect): 1000 nM
Compound 4: middle estimate off by 33-fold (1.52 log units), on the low side, outside the stated range (above it).
By their numbers in this assay, from the lowest: compound 3; then compound 1; then compounds 2 and 4 (each within the scatter of the next).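

In this assay, the new step on the sulfonyl sulfur is a 1000-fold higher number from compound 3 to compound 4 (3.00 log units; beyond the scatter), so a halogen-bearing phenyl on that sulfur does not by itself keep the number low. The 3-chlorophenyl also falls short of the 4-nitrophenyl, with a 10-fold higher number from compound 1 to compound 4 (1.00 log units; beyond the scatter), and it shows no change at the digits printed from compound 2 to compound 4 (within the scatter), which places it level with the 2-methylphenyl and leaves the 2-fluorophenyl of compound 3 alone at the low end among the four compounds. Nothing shown accounts for this sharp difference between the two halogen-bearing groups.

This step changes the halogen and its printed ring position together, so the compounds shown cannot separate the two. As far as these compounds go, a 2-chlorophenyl and a 3-fluorophenyl would be needed to tell them apart, and how an unsubstituted phenyl would compare also remains open.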